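Notes on compound 2 and its butoxy analogue

A few compounds are considered here, and "the series" means these few. Any claim that something is new, unique, unknown or untested is made for them only; others in the source may bear on it.

Compound 1, `O=C(Nc1ccc(Cc2ccccc2)cc1)Nc1nn(C(=O)Nc2ccc(Cc3ccccc3)cc2)c2ccccc12`: in a functional assay on MDA-MB-231 cells (Homo sapiens) for inhibition, read by sulforhodamine B assay, with a stated time of 48 h (on this read-out higher numbers stand for weaker inhibition of growth and lower numbers for stronger inhibition of growth), compound 1 gives 47100 nM.
Compound 2, `Nc1nn(C(=O)Nc2ccc(Cc3ccccc3)cc2)c2ccccc12`: in this assay compound 2 gives 847 nM.

Among the compounds with values here, compound 2 stands lowest of the two numbers; compound 1 is the only neighbour and its number is far higher, beyond the scatter. Compound 3, `CCCCOc1ccc(NC(=O)n2nc(N)c3ccccc32)cc1`, differs from compound 2 by butoxy in place of benzyl on an aromatic carbon. Within the data shown here, no measured pair shows this change, so nothing anchors its size; a shift of modest size is expected, more likely towards a higher number than a lower one. The step from compound 2 to compound 3 is expected to be a 1.5-fold higher number from compound 2 to compound 3 (0.19 log units; within the scatter). Compound 3 is estimated at 1300 nM, within 400 nM to 4500 nM.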

Compound 3, concentration for 50% growth inhibition: 13800 nM
Beside the measured number, compound 3's estimate is 11-fold (1.03 log units) below it, and the stated range ends below it.
By their numbers in this assay, from the lowest: compound 2; then compound 3; then compound 1.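

Butoxy in place of benzyl on this aromatic carbon, para to a large group, brings a 16-fold higher number from compound 2 to compound 3 (1.21 log units; beyond the scatter), the first sign that growth inhibition in this series responds to the group at this place. The change removes a six-membered aromatic ring of carbon only and adds an oxygen-linked open chain, and this single pair cannot separate those two differences. Nothing measured here accounts for the step.

Still open, as far as these compounds go, is whether a benzyloxy or phenoxy group, which would keep an aromatic ring, behaves like benzyl or like butoxy. Also open, from the compounds shown here alone, is how a shorter alkoxy chain or an amine would behave at this place.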